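The source may hold more compounds than are shown below. What is called first, only, known or untested is meant among the compounds shown, and "the series" means these compounds.

Three compounds built on one shared core were tested in an ADME assay on BHK-21 cells (Mesocricetus auratus) for cytotoxicity, with a stated time of 3 days; on this read-out higher numbers stand for lower toxicity in this test and lower numbers for higher toxicity in this test. Compound 1 `O=C(CCSc1nnc(-c2ccncc2)s1)Nc1ccc(Cl)cc1` gives 8210 nM. For compound 2 `O=C(CCSc1nnc(-c2ccncc2)s1)Nc1ccccc1` this assay reports only a limit, > 50000 nM. For compound 3 `CC(CSc1nnc(-c2ccncc2)s1)C(=O)Nc1ccccc1` this assay likewise reports only a limit, > 50000 nM. Compound 1 differs from compound 2 by chloro in place of hydrogen on an aromatic carbon, a change that gave an at least 6.0-fold lower number from compound 2 to compound 1 (0.78 log units; beyond the scatter). Compound 3 differs from compound 2 by methyl in place of hydrogen on a saturated chain carbon bound to a carbonyl carbon and a saturated chain carbon, and that step is a step that the two limits leave unreadable from compound 2 to compound 3. Compound 4 `CC(CSc1nnc(-c2ccncc2)s1)C(=O)Nc1ccccc1Cl` is not yet measured; it differs from compound 3 by chloro in place of hydrogen on an aromatic carbon, the same kind of change as between compound 2 and compound 1, though here the place is ortho to a large group rather than para to a large group. That earlier step is an at least 6.0-fold lower number from compound 2 to compound 1 (0.78 log units; beyond the scatter). On that basis compound 4 is expected to show an at least 3.3-fold lower number from compound 3 to compound 4 (0.52 log units; beyond the scatter). Compound 4 is estimated at 15000 nM, between 5000 nM and 50000 nM.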

Compound 4, half-maximal cytotoxic concentration: > 50000 nM
Compound 4: a limit, no number (the forecaster's own chance of this, stated with the estimate: 40%); at least 3.3-fold (0.52 log units) between middle value and limit.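

No step can be read from compound 3 to compound 4, because each gives only a limit and not a number: the limit of > 50000 nM in this assay, at which 3 of the 4 values shown sit.

Left open is whether chloro in place of hydrogen on compound 4 changes the number in this assay at all.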